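Aryl Swap on the Core of Compound 1

A few compounds are considered here, and "the series" means these few. Any claim that something is new, unique, unknown or untested is made for them only; others in the source may bear on it.

Compound 1 `Cn1c(-c2cccnc2)nc2c(NC3CCCC3)ncnc21` was examined in a functional assay on CHO cells for antagonist activity at adenosine receptor A2b (Homo sapiens), read by 33P incorporation, with a stated time of 20 min; on this read-out higher numbers stand for weaker inhibition and lower numbers for stronger inhibition. In this assay compound 1 gives only a limit, > 30000 nM, not a number (the limit of > 30000 nM in this assay, at which 1 of the 2 values shown sits). Compound 2 `CCCn1c(-c2ccccc2)nc2c(N)ncnc21` carries a phenyl and a free amine on the shared core; in this assay compound 2 gives 1040 nM. Compound 3 `Cn1c(-c2ccccc2Cl)nc2c(NC3CCCC3)ncnc21` differs from compound 1 in one place: 2-chlorophenyl in place of pyridin-3-yl on an aromatic carbon. Among the measured compounds shown here, no measured pair isolates this change, so the size of the step is uncertain. The step of an at least 3.0-fold lower number from compound 1 to compound 3 (0.47 log units; beyond the scatter) is expected to lean toward stronger inhibition. Compound 3 is estimated at 10000 nM, within a range from 2000 nM to 60000 nM.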

Compound 3, inhibition constant: > 30000 nM
Compound 3 gave a limit, no number; the forecaster's own chance of this, stated with the estimate: 40%; middle value at least 3.0-fold (0.47 log units) away from the limit.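

No step can be read between compound 1 and compound 3 in this assay, since each gives only a limit: the limit of > 30000 nM in this assay, at which 2 of the 3 values shown sit. The compounds shown leave open whether 2-chlorophenyl in place of pyridin-3-yl changes inhibition at all.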